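The compounds below may be only part of what the source reports. "The series", "measured", "known", "first", "only" and "open" are said of these compounds alone.

Measured so far:
- compound 1, `CC(=O)N1N=C(c2ccc(N(C)C)cc2)OC1c1cc(C)c(C)c(C)c1`, 5.7 uM
- compound 2, `COc1cc(C2OC(c3ccc(N(C)C)cc3)=NN2C(=O)COC(C)=O)cc(OC)c1OC`, 0.072 uM

In a functional assay on NCI-H460 cells (Homo sapiens) (on this read-out lower numbers stand for an effect already at smaller amounts and higher numbers for an effect only at larger amounts of compound), compound 2 gives the lower of these two numbers, and the gap to compound 1 is well beyond the usual scatter. Compound 3, `COc1cc(C2OC(c3ccc(N(C)C)cc3)=NN2C(=O)CNC(C)=O)cc(OC)c1OC`, has not been measured yet. It differs from compound 2 by acetamido in place of acetoxy on a saturated chain carbon bound to a carbonyl carbon. Among the measured compounds shown here, no measured pair shows this kind of change, so nothing here tells its size. The expected step is a 1.4-fold higher number from compound 2 to compound 3 (0.14 log units; within the scatter) in this assay, small and not beyond the scatter. Compound 3 is expected to give about 0.1 uM, with a range from 0.03 uM to 0.4 uM.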

Compound 3, concentration for half-maximal effect: 0.48 uM
Compound 3: the middle estimate sits 4.8-fold (0.68 log units) below what was measured, and the stated range ends below it.
By their numbers in this assay, from the lowest: compound 2; then compound 3; then compound 1.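

Among the compounds shown here, this pair is the first to isolate one change at this place: acetamido in place of acetoxy on a saturated chain carbon bound to a carbonyl carbon gives a 6.7-fold higher number from compound 2 to compound 3 (0.82 log units; beyond the scatter) in this assay. Acetoxy and acetamido have equal heavy-atom counts, so even a swap that leaves the size of the group unchanged can matter here. No measured evidence explains this step.

Going by these compounds, how an amine, a carboxylic acid or a longer chain would read out at this place stays open. So does whether the same swap would give a similar step on the core of compound 1.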